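Working notes: benzoyl on the amide-type nitrogen, compound 4

A few compounds are considered here, and "the series" means these few. Any claim that something is new, unique, unknown or untested is made for them only; others in the source may bear on it.

Compound 1 `Cc1cn([C@@H]2O[C@@H]3COC(=O)[C@]3(OS(C)(=O)=O)[C@H]2O)c(=O)[nH]c1=O` is the unsubstituted member; in a functional assay on HEL cells (Homo sapiens) for cytotoxicity, read by microscopy (a higher number here means that more compound is tolerated, a lower number that less compound is tolerated), compound 1 gives only a limit of the assay, >= 400000 nM. Compound 2 `CCOC(=O)CNC(=O)NC1=CS(=O)(=O)O[C@@]12[C@@H](CO[Si](C)(C)C(C)(C)C)O[C@@H](n1cc(C)c(=O)n(C)c1=O)[C@@H]2O[Si](C)(C)C(C)(C)C` gives 16000 nM in this assay, and compound 3 `Cc1cn([C@@H]2O[C@H](CO[Si](C)(C)C(C)(C)C)[C@@]3(OS(=O)(=O)C=C3NC(N)=O)[C@H]2O[Si](C)(C)C(C)(C)C)c(=O)n(C)c1=O` gives 16000 nM in this assay, so compound 2 stands level with compound 3 at the digits shown. Compound 4 `Cc1cn([C@@H]2O[C@H](CO[Si](C)(C)C(C)(C)C)[C@@]3(OS(=O)(=O)C=C3NC(=O)NC(=O)c3ccccc3)[C@H]2O[Si](C)(C)C(C)(C)C)c(=O)n(C)c1=O` differs from compound 2 by benzoyl in place of (ethoxycarbonyl)methyl on an amide-type nitrogen. Among the measured compounds shown here, only one measured step touches this nitrogen, no change at the digits printed from compound 2 to compound 3 (within the scatter), where hydrogen took the place of the same leaving group and the reading did not move beyond the scatter. A change on this nitrogen is therefore expected to leave the reading essentially unchanged, with an expected step of no change at the digits printed from compound 2 to compound 4 (within the scatter). Compound 4 is estimated at 16000 nM, with a range from 5000 nM to 50000 nM.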

Compound 4, minimum cytotoxic concentration: >= 80000 nM
Compound 4 was reported as a limit; the forecaster's own chance of this, stated with the estimate: 5%; at least 5.0-fold (0.69 log units) between middle value and limit.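

This nitrogen does not leave the reading unmoved whatever it carries: benzoyl gives an at least 5.0-fold higher number from compound 2 to compound 4 (0.69 log units; beyond the scatter), and in place of hydrogen it gives an at least 5.0-fold higher number from compound 3 to compound 4 (0.69 log units; beyond the scatter). Hydrogen in place of (ethoxycarbonyl)methyl had shown no change at the digits printed from compound 2 to compound 3 (within the scatter), so the first change beyond the scatter at this position comes with benzoyl. Both new steps rest on a limit for compound 4 and fix only a minimum size: the limit of >= 80000 nM in this assay, at which 1 of the 4 values shown sits.

As far as these compounds go, the true size of the step stays open. So does whether the carbonyl or the aromatic ring of benzoyl carries it, which an acetyl group or a benzyl group on this nitrogen would separate.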